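The source may hold more compounds than are shown below. What is called first, only, known or untested is meant among the compounds shown, and "the series" means these compounds.

Working notes on the series. The shared core carries a nitrile, a phenyl ring and a sulfanylmethyl triazole bearing a chlorobenzyl group; the variable part is the aryl group on the anilino nitrogen. Compound 1 `N#Cc1c(Nc2ccccc2Cl)nc(SCc2cn(Cc3ccccc3Cl)nn2)nc1-c1ccccc1` gives 28500 nM in a functional assay on ECa-109 cells (Homo sapiens) for inhibition, read by MTT assay, with a stated time of 72 h; on this read-out higher numbers stand for weaker inhibition and lower numbers for stronger inhibition. Compound 2 `N#Cc1c(Nc2cccc(Cl)c2)nc(SCc2cn(Cc3ccccc3Cl)nn2)nc1-c1ccccc1` gives 24400 nM in this assay, and the step of a 1.2-fold lower number from compound 1 to compound 2 (0.07 log units; within the scatter) stays within the scatter. Compound 3 `COc1ccccc1Nc1nc(SCc2cn(Cc3ccccc3Cl)nn2)nc(-c2ccccc2)c1C#N` gives 9670 nM in this assay, the lowest number of the three; the steps of a 2.9-fold lower number from compound 1 to compound 3 (0.47 log units; beyond the scatter) and a 2.5-fold lower number from compound 2 to compound 3 (0.40 log units; beyond the scatter) are both modest but beyond the scatter.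

Compound 4 `Cc1cccc(Nc2nc(SCc3cn(Cc4ccccc4Cl)nn3)nc(-c3ccccc3)c2C#N)c1` is not yet measured. It differs from compound 3 by 3-methylphenyl in place of 2-methoxyphenyl on a nitrogen on an aromatic ring. The bearing steps are those into compound 3 from the two chlorophenyl analogues, each modest and both pointing to the 2-methoxyphenyl compound as the low end. Removing that group in favour of 3-methylphenyl, which resembles the 3-chlorophenyl of compound 2, is expected to give back part of that gain, a modest rise a 1.9-fold higher number from compound 3 to compound 4 (0.27 log units; within the scatter). Compound 4 is therefore estimated at 18000 nM in this assay, with a range from 8000 nM to 40000 nM.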

Compound 4, half-maximal inhibitory concentration: 15600 nM
Estimate against measurement, compound 4: 1.2-fold (0.06 log units) above; the range from low to high includes it.
By their numbers in this assay, from the lowest: compounds 3, 4, 2 and 1 (each within the scatter of the next, the first and the last beyond it).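

On a nitrogen on an aromatic ring, 3-methylphenyl cannot be separated in this assay from any of the three earlier groups: 2-methoxyphenyl (a 1.6-fold higher number from compound 3 to compound 4 (0.21 log units; within the scatter)), 3-chlorophenyl (a 1.6-fold lower number from compound 2 to compound 4 (0.19 log units; within the scatter)) and 2-chlorophenyl (a 1.8-fold lower number from compound 1 to compound 4 (0.26 log units; within the scatter)). The only differences beyond the scatter remain those of compound 3 against compounds 1 and 2, and compound 4 lies within the scatter of all three. Nothing available gives a reason for these readings.

Going by these compounds, whether 3-methoxyphenyl would read with compound 3 or with compound 4 stays open, so the effect of the methoxy group cannot be separated from that of its place on the ring. Also open, on these data alone, is whether an amine or a carboxylic acid on this ring would give a step beyond the scatter.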